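The source may report more compounds than this note shows. Statements on the series, on what has been measured and on what is new or still open speak of the compounds shown alone.

Compound 1 `CC(=O)NC1CC(C)N(C(=O)c2ccccc2)c2ccccc21` gives 3620 nM in an assay on HEK293 cells for displacement of a labelled ligand from prostaglandin D2 receptor 2 (Homo sapiens), read by scintillation counting, in the presence of a further agent that is not named here; on this read-out higher numbers stand for weaker inhibition and lower numbers for stronger inhibition.
Compound 2 `CCN(C(C)=O)C1CC(C)N(C(=O)c2ccccc2)c2ccccc21` gives 250 nM in this assay.

Compound 2 stands at the lower of the two numbers; the step of a 14-fold lower number from compound 1 to compound 2 (1.16 log units; beyond the scatter) separates it from compound 1. Compound 3 `CC(=O)N(Cc1ccccc1)C1CC(C)N(C(=O)c2ccccc2)c2ccccc21` has not yet been measured in this assay. It differs from compound 2 in one place: phenyl in place of methyl on a saturated chain carbon bound to an amide-type nitrogen. Among the measured compounds shown here, no measured step alters this group itself. For the measured compounds named here, the only measured step, a 14-fold lower number from compound 1 to compound 2 (1.16 log units; beyond the scatter), put a chain on the same amide-type nitrogen that carries the benzyl in compound 3, and it moved the number down strongly. That step compares hydrogen with ethyl rather than methyl with phenyl; it bears on compound 3 only indirectly. The account therefore expects for compound 3 a step of a 1.7-fold lower number from compound 2 to compound 3 (0.22 log units; within the scatter) in this assay, with little confidence in its size. The estimate for compound 3 in this assay is 150 nM, with a range from 40 nM to 700 nM.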

Compound 3, half-maximal inhibitory concentration: 430 nM
Compound 3: middle estimate off by 2.9-fold (0.46 log units), on the low side; the measured number falls inside the stated range.
By their numbers in this assay, from the lowest: compounds 2 and 3 (each within the scatter of the next); then compound 1.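

Putting benzyl in place of hydrogen on the amide-type nitrogen also lowers the number (an 8.4-fold lower number from compound 1 to compound 3 (0.93 log units; beyond the scatter)), so the drop in this assay is no longer tied to ethyl alone. Phenyl in place of methyl on the saturated chain carbon gives only a change within the scatter (a 1.7-fold higher number from compound 2 to compound 3 (0.24 log units; within the scatter)), so ethyl and benzyl at this place cannot be told apart here, even though the change adds a six-membered aromatic ring. No supporting evidence is available to explain this result.

The compounds shown leave open how a plain methyl or a longer chain such as phenethyl would read on this nitrogen. They also leave open whether an amine or a carboxylic acid carried on the phenyl of the benzyl would shift the number in either direction.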